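The source may hold more compounds than are shown below. What is called first, only, known or untested is meant among the compounds shown, and "the series" means these compounds.

Measured so far:
- compound 1 `O=C(N[C@@H](CO)C(=O)NO)c1ccc(C#Cc2ccccc2)cc1`: 2 in a physicochemical assay for lipophilicity; a lower number here means a more polar compound, a higher number a more lipophilic compound
- compound 2 `O=C(NC1(C(=O)NO)CCS(=O)(=O)CC1)c1ccc(C#Cc2ccccc2)cc1`: 3 in this assay

Compound 1 stands lowest of the two numbers in this assay; the value of compound 2 lies higher, beyond the scatter. Compound 3 `CSC[C@H](NC(=O)c1ccc(C#Cc2ccccc2)cc1)C(=O)NO` has not yet been measured in this assay. Its difference from compound 1: methylsulfanyl in place of hydroxy on a saturated chain carbon, two bonds along the chain from an amide-type nitrogen and a carbonyl carbon. For the measured compounds named here, no step between measured compounds covers this change, so no measured size can be read for it. The step of a number 1.00 log units higher from compound 1 to compound 3 (beyond the scatter) is expected to go upward, beyond the scatter. Compound 3 is estimated at 3, within a range of 2.4 to 3.6.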

Compound 3, distribution coefficient: 3
Compound 3: middle estimate and measured number agree at the digits printed, within the range that was stated.
By their numbers in this assay, from the lowest: compound 1; then compounds 2 and 3 (each within the scatter of the next).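

In this assay, for the compounds shown here, the exchange of hydroxy for methylsulfanyl on this saturated chain carbon gives a number 1.00 log units higher from compound 1 to compound 3 (beyond the scatter) and provides the first single-place step. The change from hydroxymethyl to (methylsulfanyl)methyl therefore moves the number beyond the scatter, while one hydrogen-bond donor leaves and neither group carries a net charge. No supporting data bear on the origin of this step.

On these data alone, whether the step follows the loss of the donor or the entry of sulfur remains open; a methoxy group at this place would help separate the two. As far as these compounds go, the response to an amine, a carboxylic acid or a longer chain at this place also remains open.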